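The source may report more compounds than this note shows. Statements on the series, on what has been measured and on what is new or still open speak of the compounds shown alone.

Compound 3 `C=CCC/C(C)=N\Nc1nc(-c2cccc([N+](=O)[O-])c2)cs1` sits in the middle of a small set of three close relatives that share one core and differ only in the group attached to a saturated chain carbon bound to a carbon with a double bond to nitrogen. In an assay on isolated protein for inhibition of Amine oxidase [flavin-containing] B (Homo sapiens), read by fluorescence, with a stated time of 20 min (a lower number here means a stronger inhibitor, a higher number a weaker inhibitor), compound 3 gives 101 nM. Compound 1 `CC(C)=NNc1nc(-c2cccc([N+](=O)[O-])c2)cs1`, which carries hydrogen at that carbon, gives 716 nM, and compound 2 `C/C(CC(C)C)=N/Nc1nc(-c2cccc([N+](=O)[O-])c2)cs1`, which carries isopropyl there, gives 12 nM. The steps between them are a 7.1-fold lower number from compound 1 to compound 3 (0.85 log units; beyond the scatter), an 8.4-fold higher number from compound 2 to compound 3 (0.93 log units; beyond the scatter) and a 60-fold lower number from compound 1 to compound 2 (1.78 log units; beyond the scatter), so compound 3 stands second highest of the three numbers, with compound 1 nearest and compound 2 furthest.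

Compound 4 `CCCC/C(C)=N\Nc1nc(-c2cccc([N+](=O)[O-])c2)cs1` differs from compound 3 by ethyl in place of vinyl on a saturated chain carbon, two bonds along the chain from a carbon with a double bond to nitrogen. None of the three measured steps touches this end of the chain; all three swap the whole group at the first carbon, and those swaps moved the numbers by modest to large amounts. Exchanging vinyl for ethyl further out is a smaller change than any of them, so the expectation for a 1.4-fold lower number from compound 3 to compound 4 (0.16 log units; within the scatter) in this assay is a shift of no more than modest size, in no firmly known direction. Compound 4 is therefore expected to give about 70 nM, within the range 20 nM to 250 nM.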

Compound 4, half-maximal inhibitory concentration: 118 nM
Compound 4: middle estimate off by 1.7-fold (0.23 log units), on the low side, and the stated range covers the measured number.
By their numbers in this assay, from the lowest: compound 2; then compounds 3 and 4 (each within the scatter of the next); then compound 1.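

With ethyl in place of vinyl, this assay gives a 1.2-fold higher number from compound 3 to compound 4 (0.07 log units; within the scatter), so in this pair the double bond of the vinyl group can be lost with no change beyond the scatter, and the fully saturated propyl chain of compound 4 serves as well as the unsaturated chain of compound 3. The large gap to the isopropyl compound also remains without that double bond, at a 9.8-fold higher number from compound 2 to compound 4 (0.99 log units; beyond the scatter), which makes it a direct comparison of isopropyl with propyl at the saturated chain carbon bound to a carbon with a double bond to nitrogen, while a 6.1-fold lower number from compound 1 to compound 4 (0.78 log units; beyond the scatter) shows that propyl still gives a lower number than hydrogen there. No supporting measurement is available to explain any of these differences.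

The compounds shown leave open what a longer chain, such as pentyl, would give at this carbon, and whether a bulkier branched group, such as tert-butyl, would go beyond isopropyl. They also leave open how an amine or a carboxylic acid placed there would compare with these purely carbon groups.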